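A few compounds are considered here, and "the series" means these few. Any claim that something is new, unique, unknown or untested is made for them only; others in the source may bear on it.

Measured compounds in a functional assay on cells (Leukemia cell, Homo sapiens) for cytotoxicity, read by sulforhodamine B assay, with a stated time of 48 h; a higher number here means a weaker inhibitor of growth, a lower number a stronger inhibitor of growth:

Compound 1, `CN(C)c1ccc(C2CC(c3ccccc3)=NN2C2=NC(=O)/C(=C3\C(=O)Nc4ccc(Br)cc43)S2)cc1`, gives 310 nM.
Compound 2, `CN(C)c1ccc(C2CC(c3ccccc3)=NN2C2=NC(=O)/C(=C3\C(=O)Nc4ccc(Cl)cc43)S2)cc1`, gives 340 nM.
Compound 3, `COc1ccc(-c2cc(-c3ccc(Cl)cc3)n(C3C(=O)Nc4ccc(Br)cc43)n2)cc1`, gives 12400 nM.

Compound 1 and compound 2 share one core and differ in a single place: chloro in place of bromo on an aromatic carbon. That change produced a 1.1-fold higher number from compound 1 to compound 2 (0.04 log units; within the scatter), so the two values are read as the same within the scatter of this assay. Compound 3 is built on a different core; how the core of compound 3 differs from the core of compound 1 is not broken down here. Its value in this assay is the highest of the three, and its nearest neighbour is compound 2, at a distance that lies beyond the scatter.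

Compound 4, `COc1ccc(-c2cc(-c3ccc(Cl)cc3)n(C3C(=O)Nc4ccc(Cl)cc43)n2)cc1`, has not yet been measured. It differs from compound 3 in one place: chloro in place of bromo on an aromatic carbon. The place of this change, word for word, is the same as the place of the change from compound 1 to compound 2, so the same change is made on the core of compound 3 that was made on the core of compound 1. The step expected from compound 3 to compound 4 in this assay is therefore a 1.0-fold higher number from compound 3 to compound 4 (0.02 log units; within the scatter), and that expectation rests on the measured step of a 1.1-fold higher number from compound 1 to compound 2 (0.04 log units; within the scatter), which stayed within the scatter. For compound 4 the value expected in this assay is 13000 nM, with the likely range running from 6500 nM to 27000 nM.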

Compound 4, concentration for 50% growth inhibition: 28000 nM
Beside the measured number, compound 4's estimate is 2.2-fold (0.33 log units) below it, outside the stated range (above it).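

In this assay, chloro in place of bromo on an aromatic carbon of the core of compound 3 gave a 2.3-fold higher number from compound 3 to compound 4 (0.35 log units; beyond the scatter), a modest step. Set beside the same change on the core of compound 1, this step cannot be told apart from the earlier one, so these two cores give no sign that the change behaves differently from one to the other: the same change on two cores in this assay, a 1.1-fold higher number (0.04 log units; within the scatter) from compound 1 to compound 2 and a 2.3-fold higher number (0.35 log units; beyond the scatter) from compound 3 to compound 4, 2.1-fold (0.31 log units) apart, within the scatter of two such steps This does not show that the two steps are equal or that the change will carry to any other core, since the comparison rests on a single pair for each core, and a small difference between the two cores is neither shown nor ruled out, with one step lying within the scatter and the other beyond it.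

The compounds shown leave open how a fluoro group, a nitrile or an amine would read at the same place on either core, so the comparison reaches no further than chloro and bromo. They also leave open whether the step from bromo to chloro would keep its size on a third core, where a further pair could show whether the agreement seen here holds more widely.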